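The source may hold more compounds than are shown below. What is called first, only, known or untested is meant among the compounds shown, and "the series" means these compounds.

The measured compounds:
compound 1 `COc1ccc(C(=O)/C=C/c2ccc(OCc3cn(Cc4ccccc4Br)nn3)cc2)cc1` — 50%
compound 2 `O=C(/C=C/c1ccc(OCc2cn(Cc3ccccc3)nn2)cc1)c1ccc([N+](=O)[O-])cc1` — "not active" (no number reported)

In a functional assay on MIA PaCa-2 cells (Homo sapiens) for inhibition, read by MTT assay, with a stated time of 48 h, tested at 10 uM (a lower number here means less inhibition of growth, a higher number more inhibition of growth at the concentration tested), compound 2 stands without a single number; it is reported as "not active" (no number reported). Compound 1 in this assay gives 50%. Within the data shown here, the two compounds differ in more than one place, so their values show only that one carries a number and the other does not.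

Compound 3 `O=C(/C=C/c1ccc(OCc2cn(Cc3ccccc3Br)nn2)cc1)c1ccc([N+](=O)[O-])cc1` differs from compound 2 by bromo in place of hydrogen on an aromatic carbon on the benzyl group of the triazole. Among the measured compounds shown here, no step between measured compounds covers this change on its own. Since compound 1, which carries the same 2-bromobenzyl group, gives 50% in this assay, some gain in growth inhibition beyond the scatter is expected for compound 3, though the nitro-bearing compound 2 remains the closer relative. Compound 3 is therefore estimated at 25% in this assay, within a range from 0% to 55%.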

Compound 3, percent growth inhibition at one concentration: 34%
Beside the measured number, compound 3's estimate is 9 percentage points below it; the measured number falls inside the stated range.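

In this assay compound 2 is reported as "not active" (no number reported) and compound 3 gives 34%, so with bromo in place of hydrogen on the benzyl group, the nitro-bearing compound carries a number, although no step can be read for this pair. Among these compounds, with the 2-bromobenzyl group held constant, nitro in place of methoxy on an aromatic carbon gives a number 16 percentage points lower from compound 1 to compound 3 (beyond the scatter), the first step that can be read in this assay. No measurement shown here accounts for either observation.

The compounds shown leave open whether chloro or an amine on the same aromatic carbon of the benzyl group would match bromo. They also leave open how a plain benzyl group would read alongside the methoxy group of compound 1.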